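Compound 4: bromo in place of cyano, expected inhibition

The source may report more compounds than this note shows. Statements on the series, on what has been measured and on what is new or still open speak of the compounds shown alone.

Measured compounds:
Compound 1, `O=[N+]([O-])c1ccccc1CNc1cccc2[nH]ncc12`, gives 65% in an assay for inhibition of Indoleamine 2,3-dioxygenase 1 (Homo sapiens), with stated times of 10 min and 60 min, tested at 100 uM; a higher number here means a stronger effect of the compound at the concentration tested, a lower number a weaker effect.
Compound 2, `N#Cc1cc(NCc2ccccc2[N+](=O)[O-])c2cn[nH]c2c1`, gives 17% in this assay.
Compound 3, `O=[N+]([O-])c1cc(Br)c(F)cc1CNc1cc(C(F)(F)F)cc2[nH]ncc12`, gives 64% in this assay.

Compound 2 stands lowest of the three numbers in this assay; its gaps to compound 3 and to compound 1 both lie beyond the scatter, and the gap to compound 1 is the larger of the two.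

Compound 4, `O=[N+]([O-])c1ccccc1CNc1cc(Br)cc2[nH]ncc12`, differs from compound 2 in one place: bromo in place of cyano on an aromatic carbon. Going by the values given here, the only measured step at this place is a number 48 percentage points lower from compound 1 to compound 2 (beyond the scatter), the loss that cyano brought in relation to hydrogen. Among the compounds with values here, no measured pair compares bromo with cyano directly. Compound 3, which carries trifluoromethyl at this place together with further groups on the other ring, gives 64% in this assay, close to the value of compound 1; the low number of compound 2 thus seems tied to the cyano group rather than to any substitution at this place. Removing cyano for bromo is therefore expected to recover most of that loss, a step of a number 38 percentage points higher from compound 2 to compound 4 (beyond the scatter). Compound 4 is estimated at 55% in this assay, within 25% to 80%.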

Compound 4, a percentage reported as inhibition, at one concentration (the size of the read-out at that concentration, not a potency): 83%
Estimate against measurement, compound 4: 28 percentage points below; the whole stated range lies below it.
By their numbers in this assay, from the lowest: compound 2; then compounds 3 and 1 (each within the scatter of the next); then compound 4.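

At this aromatic carbon the outcome depends on the group, and substitution does not simply cost inhibition: in this assay, bromo in place of cyano gives a number 66 percentage points higher from compound 2 to compound 4 (beyond the scatter). The earlier compounds shown here showed only a loss from a group placed here in a one-place comparison, whereas bromo in place of hydrogen gives a number 18 percentage points higher from compound 1 to compound 4 (beyond the scatter). Among compounds 1, 2 and 4, which differ only at this carbon, hydrogen therefore lies between two groups that move the number in opposite directions.

From the compounds shown here alone, whether groups such as chloro, methoxy or an amine at this carbon would follow bromo or cyano remains open, as does whether the gain from bromo would persist with changes elsewhere on the core. Nothing available explains why bromo and cyano differ in this way.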